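The source may report more compounds than this note shows. Statements on the series, on what has been measured and on what is new or still open speak of the compounds shown alone.

Compound 1 `N#CC1=C(NC(=O)c2ccccc2)N(c2ccc(S(N)(=O)=O)cc2)C2=C(C(=O)CCC2)C1c1ccc(Cl)cc1Cl` is the higher of the two measured compounds: in a functional assay on Ehrlich cells (Mus musculus) for cytotoxicity, read by trypan blue exclusion, with a stated time of 2 h, tested at 25 ug/mL (on this read-out lower numbers stand for a weaker effect and higher numbers for a stronger effect at the one concentration tested), compound 1 gives 60%. Among the compounds with values here, compound 2 `CC(=O)CC(=O)NC1=C(C#N)C(c2ccc(Cl)cc2Cl)C2=C(CCCC2=O)N1c1ccc(S(N)(=O)=O)cc1` gives 44% in this assay, and the only measured step, a number 16 percentage points lower from compound 1 to compound 2 (beyond the scatter), swaps the six-membered aromatic ring of carbon only on the carbonyl carbon for a chain. Compound 3 `CCO/C=N/C1=C(C#N)C(c2ccc(Cl)cc2Cl)C2=C(CCCC2=O)N1c1ccc(S(N)(=O)=O)cc1` is not yet measured. It differs from compound 1 in the same region of the shared core: a group of 5 heavy atoms (3 carbon, 1 nitrogen, 1 oxygen; no ring) in place of a group of 9 heavy atoms (7 carbon, 1 nitrogen, 1 oxygen; one six-membered aromatic ring of carbon only), on a double-bonded ring carbon. Within the data shown here, the one measured step bears on this change, since it also removed the aromatic ring from the group on that double-bonded ring carbon and gave a modest fall. A fall of similar size is therefore expected for compound 3, because a number 16 percentage points lower from compound 1 to compound 2 (beyond the scatter) points that way, though the incoming group here is smaller and lacks the hydrogen-bond donor. The expected step is a number 15 percentage points lower from compound 1 to compound 3 (beyond the scatter). Compound 3 is estimated at 45%, with a range from 28% to 62%.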

Compound 3, a percentage reported as activity, at one concentration (the size of the read-out at that concentration, not a potency): 30%
Compound 3: middle estimate off by 15 percentage points, on the high side; measured number inside the range.
By their numbers in this assay, from the lowest: compound 3; then compound 2; then compound 1.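

The result shows that the outcome at this double-bonded ring carbon depends on more than whether the aromatic ring is present. Replacing the benzamido group with the ethoxy-containing group in this assay gives a number 30 percentage points lower from compound 1 to compound 3 (beyond the scatter), a larger fall than compound 2 showed. Among the two groups without a ring, the read-out still moves, with a number 14 percentage points lower from compound 2 to compound 3 (beyond the scatter), so the ring's absence alone does not set the level.

No measurement here gives a cause for these falls, and ring loss, group size and the missing amide hydrogen remain tangled together in these compounds. A plain amine or an acetamido group on this carbon would help show whether keeping the amide hydrogen without a longer chain holds the read-out up.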